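This account rests on a few compounds, and the source may have more. Where it says the series, first, only, none or still open, it means among the compounds named here.

Working notes on the series, read in an ADME assay on microsomes from liver (Homo sapiens) for metabolic stability; on this read-out lower numbers stand for slow clearance and higher numbers for fast clearance. Compound 1 `COc1ccc([C@H](C)NC(=O)Cn2nnc3ccccc3c2=O)cc1` gives 13 mL/min/kg, and compound 2 `C[C@H](NC(=O)Cn1nnc2ccccc2c1=O)c1ccc(F)cc1` gives 31 mL/min/kg. Compound 3 `C[C@H](NC(=O)Cn1nnc2ccccc2c1=O)c1ccc(Br)cc1` is reported only as a limit, < 9.9 mL/min/kg. The next change leads to compound 4 `C[C@H](NC(=O)Cn1nnc2ccccc2c1=O)c1ccc(OC(F)F)cc1`: difluoromethoxy in place of bromo on an aromatic carbon, para to a large group. The steps bearing on it are the modest 2.4-fold higher number from compound 1 to compound 2 (0.38 log units; beyond the scatter), the at least modest an at least 3.1-fold lower number from compound 2 to compound 3 (0.49 log units; beyond the scatter), and an at least 1.3-fold lower number from compound 1 to compound 3 (0.11 log units; that floor lies within the scatter), whose floor lies within the scatter. Each exchanges one group at this place, so a modest rise is expected, and the estimated step is an at least 1.6-fold higher number from compound 3 to compound 4 (0.20 log units; that floor lies within the scatter). For compound 4 the estimate is 16 mL/min/kg, with an expected range of 8 mL/min/kg to 32 mL/min/kg.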

Compound 4, clearance: < 9.9 mL/min/kg
Compound 4 gave a limit, no number (the forecaster's own chance of this, stated with the estimate: 20%); at least 1.6-fold (0.20 log units) between middle value and limit.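

Difluoromethoxy, para to a large group, is a second group after bromo that lowers the number relative to fluoro, with an at least 3.1-fold lower number from compound 2 to compound 4 (0.49 log units; beyond the scatter). Difluoromethyl in place of methyl on the oxygen gives an at least 1.3-fold lower number from compound 1 to compound 4 (0.11 log units; that floor lies within the scatter), so no firm change from compound 1 can be claimed. Compound 3 and compound 4 are both limits, so the step between them cannot be read: the limit of < 9.9 mL/min/kg in this assay, at which 2 of the 4 values shown sit.

From the compounds shown here alone, how far compound 3 and compound 4 lie beyond that limit stays open. Also open, going by these compounds, is how an amine, a nitrile or an ethoxy group would read at this place.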